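Ester variation in an antiproliferative series

The source may hold more compounds than are shown below. What is called first, only, known or untested is meant among the compounds shown, and "the series" means these compounds.

Measured so far:
- compound 1 `CC1=CC[C@H]2[C@H](CC[C@]2(C)O)C(C)(C)[C@@H]1CC[C@H]1[C@]2(C)CC[C@H](OC(=O)c3ccc(Cl)cc3)C(C)(C)O[C@H]2CC[C@@]1(C)O`: in a functional assay on MCF7 cells (Homo sapiens) for antiproliferative activity, read by MTT assay, with a stated time of 72 h (on this read-out higher numbers stand for weaker inhibition and lower numbers for stronger inhibition), compound 1 gives 24100 nM
- compound 2 `CC1=CC[C@H]2[C@H](CC[C@]2(C)O)C(C)(C)[C@@H]1CC[C@H]1[C@]2(C)CC/C(=N/OCc3ccccc3)C(C)(C)O[C@H]2CC[C@@]1(C)O`: compound 2 is reported only as a limit of the assay, > 50000 nM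

Compound 1 holds the only numeric value among the two results shown. Compound 2 sits at the upper limit of the assay, (the limit of > 50000 nM in this assay, at which 1 of the 2 values shown sits), and so gives no number to compare against. Going by the values given here, no measured pair in this set differs in a single place, so no step size has been observed.

Compound 3 `CC1=CC[C@H]2[C@H](CC[C@]2(C)O)C(C)(C)[C@@H]1CC[C@H]1[C@]2(C)CC[C@H](OC(=O)c3ccco3)C(C)(C)O[C@H]2CC[C@@]1(C)O` differs from compound 1 in the ester only: furan-2-yl in place of 4-chlorophenyl on a carbonyl carbon. Among the compounds with values here, with no measured step to lean on, the expected change from compound 1 to compound 3 in this assay is none beyond the scatter, with a slight lean toward weaker inhibition, a 1.3-fold higher number from compound 1 to compound 3 (0.12 log units; within the scatter). Compound 3 is therefore estimated at 32000 nM, within 12000 nM to 70000 nM.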

Compound 3, half-maximal inhibitory concentration: 25700 nM
Estimate against measurement, compound 3: 1.2-fold (0.10 log units) above; measured number inside the range.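

In this assay, the ester on the shared core now has its first readable step: furan-2-yl in place of 4-chlorophenyl on a carbonyl carbon gives a 1.1-fold higher number from compound 1 to compound 3 (0.03 log units; within the scatter). At this place, the two compounds are therefore not told apart, although one carries a six-membered aromatic ring of carbon only with chlorine and the other a five-membered aromatic ring with 1 hetero atom. Nothing measured here accounts for this outcome.

Both esters shown carry an aromatic ring on the carbonyl carbon, so it remains open whether that ring matters at all. A saturated chain such as hexyl, or a phenyl ring bearing an amine or a carboxylic acid, would test whether this place responds to any change in the ester.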